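Trimethoxyphenyl for chlorophenyl on the enone of compound 2

The compounds below may be only part of what the source reports. "The series", "measured", "known", "first", "only" and "open" are said of these compounds alone.

Compound 2 `COc1cc(-c2cc(C(=O)/C=C/c3ccc(Cl)cc3)nc3cc(-c4ccccc4)nn23)cc(OC)c1OC` gives 53900 nM in an ADME assay on HEK293 cells (Homo sapiens) for antiproliferative activity, read by MTT assay, with a stated time of 24 h; on this read-out lower numbers stand for stronger inhibition and higher numbers for weaker inhibition; it stands second highest of the three numbers, nearest compound 3 `COc1ccc(-c2cc(C(=O)/C=C/c3ccc(Cl)cc3)nc3cc(-c4ccccc4)nn23)cc1OC` at 39100 nM and furthest compound 1 `COc1ccc(C(=O)/C=C/c2cc(-c3cc(OC)c(OC)c(OC)c3)n3nc(-c4ccccc4)cc3n2)cc1` at 79800 nM, both gaps within the scatter. Compound 4 `COc1cc(/C=C/C(=O)c2cc(-c3cc(OC)c(OC)c(OC)c3)n3nc(-c4ccccc4)cc3n2)cc(OC)c1OC` differs from compound 2 by 3,4,5-trimethoxyphenyl in place of 4-chlorophenyl on a double-bonded chain carbon bound to a double-bonded chain carbon. No measured step exchanges these two groups directly; the nearest are a 1.5-fold lower number from compound 1 to compound 2 (0.17 log units; within the scatter) and a 1.4-fold lower number from compound 2 to compound 3 (0.14 log units; within the scatter), both within the scatter, so the series has shown no shift beyond the scatter across any change so far. Compound 4 is therefore expected to give 60000 nM in this assay, range 25000 nM to 150000 nM, with a 1.1-fold higher number from compound 2 to compound 4 (0.05 log units; within the scatter) estimated as no step beyond the scatter.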

Compound 4, half-maximal inhibitory concentration: 41000 nM
Estimate against measurement, compound 4: 1.5-fold (0.17 log units) above, within the range that was stated.
By their numbers in this assay, from the lowest: compounds 3, 4, 2 and 1 (each within the scatter of the next, the first and the last beyond it).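

At the place on a double-bonded chain carbon bound to a double-bonded chain carbon, 3,4,5-trimethoxyphenyl in place of 4-chlorophenyl gives a 1.3-fold lower number from compound 2 to compound 4 (0.12 log units; within the scatter) in this assay as the read-out. The earlier steps shown here did not exchange this aryl group alone, and here a group of 12 heavy atoms with 3 hydrogen-bond acceptors replaces one of 7 heavy atoms with 0 acceptors without a step beyond the scatter. No measured evidence bears on this result.

Both aryl groups leave the number within the scatter, so this place has not yet shown a shift. Going by these compounds, whether an amine or a carboxylic acid there would give a step beyond the scatter stays open.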